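Trifluoromethylphenyl replaces methoxyphenyl on a thiosemicarbazide acyl group

The compounds below may be only part of what the source reports. "The series", "measured", "known", "first", "only" and "open" are said of these compounds alone.

Measured compounds:
compound 1, `COc1cc2ncnc(NNC(=S)NC(=O)c3ccc(Cl)cc3)c2cc1OC`, 7530 nM
compound 2, `COc1cc2ncnc(NNC(=S)NC(=O)c3ccccc3OC)c2cc1OC`, 8410 nM
compound 3, `O=C(NC(=S)NNc1ncnc2ccccc12)c1ccc(F)cc1`, 2840 nM

Among the three numbers in a functional assay on CNE-2 cells (Homo sapiens) for cytotoxicity, read by MTT assay, with a stated time of 72 h (on this read-out higher numbers stand for weaker inhibition and lower numbers for stronger inhibition), compound 2 gives 8410 nM, the highest of the set; compound 1 sits closest with 7530 nM, and compound 3 is furthest with 2840 nM. Compound 4, `COc1cc2ncnc(NNC(=S)NC(=O)c3ccc(C(F)(F)F)cc3)c2cc1OC`, has not been measured. It differs from compound 2 by 4-(trifluoromethyl)phenyl in place of 2-methoxyphenyl on a carbonyl carbon.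

Among the measured compounds shown here, only one measured step bears on this: a 1.1-fold higher number from compound 1 to compound 2 (0.05 log units; within the scatter), which swapped a para-substituted aryl for the 2-methoxyphenyl and stayed within the scatter. Compound 3 carries a para-substituted aryl too, but it also differs in its core, so its value cannot be set directly against compound 2. Going back to a para-substituted aryl in compound 4 is therefore expected to move this assay little, if at all, perhaps slightly toward the number of compound 1. The estimate for compound 4 is 6500 nM, between 2500 nM and 16000 nM. This is expected to be a step of a 1.3-fold lower number from compound 2 to compound 4 (0.11 log units; within the scatter), within the scatter.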

Compound 4, half-maximal inhibitory concentration: 16500 nM
For compound 4 the middle estimate is 2.5-fold (0.40 log units) below the measured one; measured number outside the range, above it.
By their numbers in this assay, from the lowest: compound 3; then compounds 1, 2 and 4 (each within the scatter of the next, the first and the last beyond it).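

In this assay, the aryl group on the carbonyl carbon now gives its first step beyond the scatter: trifluoromethyl in place of chloro on an aromatic carbon gives a 2.2-fold higher number from compound 1 to compound 4 (0.34 log units; beyond the scatter), a modest step. The change from 2-methoxyphenyl to 4-(trifluoromethyl)phenyl, by contrast, gives a 2.0-fold higher number from compound 2 to compound 4 (0.29 log units; within the scatter), which remains within the scatter, so this position is not shown to be sensitive to that exchange, and only the swap of one substituent for another on the same aromatic carbon separates two compounds here. Nothing available explains this difference.

From the compounds shown here alone, whether an amine or a carboxylic acid on this aryl ring would shift the number further remains open. Compound 3 differs from the others in more than one place, so what its core contributes also remains unresolved.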